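Chloro to Bromo Swap: Expected Effect on Cell Growth

The source may report more compounds than this note shows. Statements on the series, on what has been measured and on what is new or still open speak of the compounds shown alone.

Measured compounds:
compound 1 `CCOC(=O)Cn1cnc2c(Cl)ncnc21` – 5270 nM
compound 2 `CCOC(=O)Cn1cnc2ncnc(Cl)c21` – 68000 nM
compound 3 `CCOC(=O)Cn1cnc2ncnc(Br)c21` – 55700 nM

All three were tested in a functional assay on HCT-116 cells (Homo sapiens) for antiproliferative activity, read by colorimetric assay and sulforhodamine B assay, with a stated time of 3 days; a lower number here means a stronger inhibitor, a higher number a weaker inhibitor. Compound 1 gives the lowest number of the three, and its gaps to compound 3 and to compound 2 both lie beyond the usual scatter of this assay, so compound 1 is the strongest inhibitor of the measured set. Compound 2 and compound 3 share a core that differs from that of compound 1 only in where the ester-bearing chain sits.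

Compound 4 `CCOC(=O)Cn1cnc2c(Br)ncnc21` has not yet been measured. It differs from compound 1 by bromo in place of chloro on an aromatic carbon. Going by the values given here, the one measured step that carries the same change is a 1.2-fold lower number from compound 2 to compound 3 (0.09 log units; within the scatter), made on the related core of compound 2 and compound 3. That step stayed within the scatter, so no step beyond the scatter is expected in this assay from compound 1 to compound 4, and the estimated change is a 1.1-fold lower number from compound 1 to compound 4 (0.02 log units; within the scatter). The value expected for compound 4 is 5000 nM, with a range from 2500 nM to 10000 nM.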

Compound 4, half-maximal inhibitory concentration: 23500 nM
Beside the measured number, compound 4's estimate is 4.7-fold (0.67 log units) below it; measured number outside the range, above it.
By their numbers in this assay, from the lowest: compound 1; then compound 4; then compounds 3 and 2 (each within the scatter of the next).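

On the core of compound 1, bromo in place of chloro on this aromatic carbon is not a neutral exchange: this assay shows a 4.5-fold higher number from compound 1 to compound 4 (0.65 log units; beyond the scatter), so here the chloro group gives the stronger inhibitor. The two cores differ only in where the ester-bearing chain sits, yet that difference is enough to separate the outcomes of one and the same halogen swap. A swap that left the number unchanged on one core therefore cannot be assumed to do so on the other: the same change on two cores in this assay, a 1.2-fold lower number (0.09 log units; within the scatter) from compound 2 to compound 3 and a 4.5-fold higher number (0.65 log units; beyond the scatter) from compound 1 to compound 4, 5.4-fold (0.74 log units) apart, beyond the scatter of two such steps

Still open, as far as these compounds go, is whether any group on this carbon would give a lower number than chloro, which iodo, an amine or a methoxy group could test. Also open, from the compounds shown here alone, is what the chain itself adds, which a carboxylic acid in place of the ester on the core of compound 1 would show.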